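This account rests on a few compounds, and the source may have more. Where it says the series, first, only, none or still open, it means among the compounds named here.

In a functional assay on A549 cells (Homo sapiens) for antiproliferative activity, with a stated time of 5 days (on this read-out lower numbers stand for stronger inhibition and higher numbers for weaker inhibition), compound 1 `Cc1ccc(-n2nc(-c3ccc4ccccc4c3)nc2N2C(=O)COC23C=CC(=O)C=C3)cc1` gives 110 nM and compound 2 `Cc1ccc(-n2nc(-c3cccc4ccccc34)nc2N2C(=O)COC23C=CC(=O)C=C3)cc1` gives 140 nM. Among the measured compounds shown here, these are the only two numbers available, and a 1.3-fold higher number from compound 1 to compound 2 (0.10 log units; within the scatter) does not separate the two compounds. Compound 3 `O=C1C=CC2(C=C1)OCC(=O)N2c1nc(-c2ccc3ccccc3c2)nn1-c1ccc(Cl)cc1` differs from compound 1 at a single place: chloro in place of methyl on an aromatic carbon. This is chloro in place of methyl on an aromatic carbon, para to a large group, or 4-methylphenyl to 4-chlorophenyl. For the measured compounds named here, the one measured step concerns a different group, naphthalen-1-yl in place of naphthalen-2-yl, so no measurement tests this exchange directly. The expectation therefore starts from compound 1 at 110 nM, and no shift beyond the scatter is expected in this assay. The estimated change is small: a 1.1-fold lower number from compound 1 to compound 3 (0.04 log units; within the scatter). For compound 3 the estimated value is 100 nM, with an expected range from 40 nM to 260 nM.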

Compound 3, half-maximal inhibitory concentration: 400 nM
Compound 3: the middle estimate sits 4.0-fold (0.60 log units) below what was measured, and the stated range ends below it.
By their numbers in this assay, from the lowest: compounds 1 and 2 (each within the scatter of the next); then compound 3.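

In this assay, the exchange of 4-methylphenyl for 4-chlorophenyl gives a real loss of inhibition (a 3.6-fold higher number from compound 1 to compound 3 (0.56 log units; beyond the scatter)), so the substituent on this aromatic carbon, para to a large group, matters to the read-out. The earlier step, which moved the naphthalene attachment, did not separate its two compounds, whereas this single replacement does, and methyl is the better of the two groups here. Methyl and chloro match on everything counted, with one heavy atom each, no hydrogen-bond donors or acceptors and no net charge, so those counts do not separate them, and nothing at hand accounts for the shift.

This one pair cannot show whether the loss is specific to chloro or would also follow from fluoro, methoxy or an amine at the same place. It also leaves open whether the same exchange would have a similar effect with the naphthalen-1-yl group of compound 2.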